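This account rests on a few compounds, and the source may have more. Where it says the series, first, only, none or still open, it means among the compounds named here.

Measured compounds:
Compound 1 `COc1cc(-c2cc(/C=C/C(=O)c3ccc(N)cc3)[nH]n2)cc(OC)c1OC` gives 29%
Compound 2 `COc1ccc(C(=O)/C=C/c2cc(-c3cc(OC)c(OC)c(OC)c3)n[nH]2)cc1OC` gives -9%

Going by the values given here, in a functional assay on Hs-578T cells (Homo sapiens) for cytotoxicity, read by sulforhodamine B assay, with a stated time of 48 h, tested at 10 uM (a lower number here means a stronger effect, a higher number a weaker effect of the compound at the concentration tested), compound 2 gives -9%, the lower of the two numbers measured so far; the nearest point is compound 1 with 29%, and the step of a number 38 percentage points lower from compound 1 to compound 2 (beyond the scatter) separates them. Compound 3 `COc1ccc(C(=O)/C=C/c2cc(-c3cc(OC)c(OC)c(OC)c3)n[nH]2)cc1` is the next member of the set. Its difference from compound 2 is hydrogen in place of methoxy on an aromatic carbon. Among the compounds with values here, the only measured step exchanges the whole aryl group on the carbonyl carbon, 3,4-dimethoxyphenyl for 4-aminophenyl, and it was large; no measured step removes a single methoxy from that ring, so the data give no direct guide to this change. The expected step is therefore a number 9 percentage points higher from compound 2 to compound 3 (within the scatter), a small one, likely within the scatter, in either direction. Compound 3 is estimated at 0%, with a range from -20% to 22%.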

Compound 3, a percentage reported as activity, at one concentration (the size of the read-out at that concentration, not a potency): 13%
Compound 3: the middle estimate sits 13 percentage points below what was measured; the measured number falls inside the stated range.
By their numbers in this assay, from the lowest: compound 2; then compound 3; then compound 1.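

In this assay the methoxy ortho to a methoxy group on the 3,4-dimethoxyphenyl ring is not a silent substituent, since its loss gives a number 22 percentage points higher from compound 2 to compound 3 (beyond the scatter) and so gives up part of the effect of compound 2. The earlier large aryl exchange can now be read in two parts. A single methoxy in place of amino already gives a number 16 percentage points lower from compound 1 to compound 3 (beyond the scatter), and the further methoxy of compound 2 extends the change in the same direction. Nothing available explains either step. The compounds shown leave open whether another group at this place, such as hydroxyl, fluorine or ethoxy, would match methoxy. They also leave open whether a third methoxy on this ring would lower the number further.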